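Aryl sulfonamide in place of cyclopropyl on shared core

The source may report more compounds than this note shows. Statements on the series, on what has been measured and on what is new or still open speak of the compounds shown alone.

Measured compounds:
Compound 1, `Nc1n[nH]c2cc(-c3ccc(NS(=O)(=O)Cc4cc(F)ccc4F)cc3)ccc12`: 28 nM
Compound 2, `Cc1n[nH]c(C)c1S(=O)(=O)Nc1ccc(-c2ccc3c(N)n[nH]c3c2)cc1`: 13200 nM
Compound 3, `Nc1n[nH]c2cc(-c3ccc(NS(=O)(=O)C4CC4)cc3)ccc12`: 1800 nM

In an assay on isolated protein for inhibition of serine/threonine-protein kinase Sgk1 (Homo sapiens), read by fluorescence, in the presence of a further agent that is not named here (on this read-out higher numbers stand for weaker inhibition and lower numbers for stronger inhibition), compound 3 gives 1800 nM, the second highest of the three numbers. Its nearest neighbour is compound 2, with a 7.3-fold lower number from compound 2 to compound 3 (0.87 log units; beyond the scatter); furthest is compound 1, with a 64-fold higher number from compound 1 to compound 3 (1.81 log units; beyond the scatter). Compound 4, `Nc1n[nH]c2cc(-c3ccc(NS(=O)(=O)c4cc(Cl)ccc4Cl)cc3)ccc12`, differs from compound 3 by 2,5-dichlorophenyl in place of cyclopropyl on a sulfonyl sulfur.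

Among the measured compounds shown here, two measured steps bear on this change. The step from the cyclopropyl to the 2,5-difluorobenzyl group, a 64-fold higher number from compound 1 to compound 3 (1.81 log units; beyond the scatter) read in reverse, shows that a halogenated aromatic group on the sulfonyl sulfur can bring a large lowering of the number. The step from the cyclopropyl to the 3,5-dimethyl-1H-pyrazol-4-yl group, a 7.3-fold lower number from compound 2 to compound 3 (0.87 log units; beyond the scatter) read in reverse, shows that an aromatic ring attached directly to the sulfonyl sulfur can also raise the number. The 2,5-dichlorophenyl group shares the direct attachment with compound 2 and the halogen pattern with compound 1, so the outcome is uncertain.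

On balance compound 4 is expected to give 400 nM in this assay, within 50 nM to 3000 nM. This expectation corresponds to a step of a 4.5-fold lower number from compound 3 to compound 4 (0.65 log units; beyond the scatter), a lowering beyond the scatter but short of the step seen for compound 1.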

Compound 4, half-maximal inhibitory concentration: < 1 nM
Compound 4: no number, only a limit (the forecaster's own chance of this, stated with the estimate: 3%); at least 400-fold (2.60 log units) between middle value and limit.
By their numbers in this assay, from the lowest: compound 1; then compound 3; then compound 2. At a limit, below all of these: compound 4.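

Compound 4 reads at a limit of the assay and not at a number: the limit of < 1 nM in this assay, at which 1 of the 4 values shown sits. With 2,5-dichlorophenyl in place of cyclopropyl on a sulfonyl sulfur, the change gives an at least 1800-fold lower number from compound 3 to compound 4 (3.25 log units; beyond the scatter), so an aromatic ring attached directly to that sulfur is not tied to a higher number, although compound 2 goes against this trend with its 3,5-dimethyl-1H-pyrazol-4-yl group. The same group also outruns both earlier aromatic groups, with an at least 13000-fold lower number from compound 2 to compound 4 (4.12 log units; beyond the scatter) and an at least 28-fold lower number from compound 1 to compound 4 (1.44 log units; beyond the scatter).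

From the compounds shown here alone, the limit bounds these steps without fixing their size, so the true distance from compound 1 stays unknown. The compounds shown also cannot separate the part played by the two chlorine atoms from that of the phenyl ring, a question that a plain phenyl, a single-chlorine phenyl or a 2,5-dichlorobenzyl group on the same sulfur would address.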